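The source may hold more compounds than are shown below. What is called first, only, known or untested is meant among the compounds shown, and "the series" means these compounds.

Compounds measured in a functional assay on Malme-3M cells (Homo sapiens) for cytotoxicity, read by MTT assay, with a stated time of 6 days; a higher number here means that more compound is needed for the effect, a lower number that less compound is needed; each value is a limit, not a number:

- compound 1 `COC(=O)c1c(-c2ccc(OC)cc2)oc2ccccc2c1=O`: > 25 ug/mL
- compound 2 `COC(=O)c1c(-c2ccc(Br)cc2)oc2ccccc2c1=O`: > 25 ug/mL
- compound 3 `COC(=O)c1c(-c2ccc([N+](=O)[O-])cc2)oc2ccccc2c1=O`: > 25 ug/mL

The starting point is compound 3 , whose > 25 ug/mL is a limit. So its place among the others cannot be ranked, and the measured set offers only (the limit of > 25 ug/mL in this assay, at which 3 of the 3 values shown sit).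

The next change gives compound 4 `COC(=O)c1c(-c2ccc(N)cc2)oc2ccccc2c1=O`, with amino in place of nitro on an aromatic carbon.

Two measured steps involve the nitro group that leaves: a step that the two limits leave unreadable from compound 1 to compound 3 and a step that the two limits leave unreadable from compound 2 to compound 3. The third is a step that the two limits leave unreadable from compound 1 to compound 2. None has a readable size, and none involves amino. They therefore support no expected direction or size in this assay, and the safest expectation is that compound 4 also gives only a limit.

The estimated change is a step that the limit leaves unreadable from compound 3 to compound 4, a figure that carries little confidence. Compound 4 is expected at about 30 ug/mL, with an estimated range of 8 ug/mL to 100 ug/mL.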

Compound 4, concentration for half-maximal effect: > 25 ug/mL
Compound 4: no number, only a limit (the forecaster's own chance of this, stated with the estimate: 70%); the middle value lies beyond the limit too.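

In this assay compound 4 gives > 25 ug/mL, which is a limit and not a number. Its steps from compound 1, compound 2 and compound 3 cannot be read, and the set offers only this: the limit of > 25 ug/mL in this assay, at which 4 of the 4 values shown sit. As far as these compounds go, whether methoxy, bromo, nitro and amino differ at all in this assay stays open.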